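Replacing a branched chain with a ring in a rat study

The source may report more compounds than this note shows. Statements on the series, on what has been measured and on what is new or still open speak of the compounds shown alone.

Compound 1, `CCCCCCC/N=C(\NC#N)Nc1cccnc1`, gives only a limit in a functional assay on the whole organism (blood, strain Wistar-Okamoto) with Rattus norvegicus as the target, with a stated time of 5 days (a higher number here means that more compound is needed for the effect, a lower number that less compound is needed), recorded as > 50 mg/kg. Compound 2, `CC(C)CC(C)/N=C(\NC#N)Nc1ccncc1`, gives 35 mg/kg in this assay. For the measured compounds named here, that is the only true number among the two results gathered so far. The other entry is the limit of > 50 mg/kg in this assay, at which 1 of the 2 values shown sits.

Compound 3, `N#CN/C(=N\C1CCCCC1)Nc1ccncc1`, has not yet been measured. It differs from compound 2 in one place: cyclohexyl in place of 1,3-dimethylbutyl on a double-bonded nitrogen. The group that leaves and the group that enters carry the same count of carbon atoms, and the change keeps the rest of compound 2 untouched. For that reason the expected step from compound 2 to compound 3 is small, no larger than the usual scatter of this assay: a 1.1-fold higher number from compound 2 to compound 3 (0.06 log units; within the scatter). Compound 3 is accordingly estimated at 40 mg/kg, within a range from 15 mg/kg to 100 mg/kg.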

Compound 3, minimum effective dose: 20 mg/kg
Compound 3: middle estimate off by 2.0-fold (0.30 log units), on the high side; low and high end bracket the measured number.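

In this assay, replacing the open chain with a ring on the double-bonded nitrogen gives a 1.8-fold lower number from compound 2 to compound 3 (0.24 log units; within the scatter). The two groups therefore cannot be told apart in this measurement, even though one is a branched chain and the other a closed ring of carbon only. For the compounds shown here, what this pair adds is a first direct comparison at this position: with the carbon count unchanged, closing the chain into a ring leaves the number inside the usual spread of repeated measurements. No measurement among these compounds gives a reason for this result.

From the compounds shown here alone, it remains open whether a smaller ring such as cyclopropyl, a ring holding oxygen such as tetrahydropyranyl, or a longer chain such as n-octyl would move the number beyond the scatter. Compound 1 differs from the other two in more than one place and gives only a limit, > 50 mg/kg, so it settles none of this.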